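Mirror-image pair in a Substance-P receptor binding series

The source may hold more compounds than are shown below. What is called first, only, known or untested is meant among the compounds shown, and "the series" means these compounds.

For the measured compounds named here, compound 1 `O=C(OCc1cc(C(F)(F)F)cc(C(F)(F)F)c1)[C@]1(c2ccccc2)CC[C@@H](N2CCC(c3ccc(F)cc3)CC2)CC1` is tested in an assay on isolated protein for displacement of a labelled ligand from Substance-P receptor (Homo sapiens) (on this read-out lower numbers stand for stronger inhibition and higher numbers for weaker inhibition), and gives 140 nM, the higher of the two numbers known so far. Compound 2 `Fc1ccc(C2CCN([C@H]3CC[C@](CNCc4cc(C(F)(F)F)cc(C(F)(F)F)c4)(c4ccccc4)CC3)CC2)cc1`, measured in this assay, gives 1.7 nM, a much lower number than compound 1, beyond the usual scatter. Compound 3 `O=C(OCc1cc(C(F)(F)F)cc(C(F)(F)F)c1)[C@]1(c2ccccc2)CC[C@H](N2CCC(c3ccc(F)cc3)CC2)CC1` is not yet measured. Compared with compound 1, the change is the two compounds have the same atoms and bonds and differ only in configuration as drawn: 2 of 2 stereo elements differ (all stereocentres are inverted: mirror images); a stereocentre at a saturated ring carbon is drawn r in compound 1 and s in compound 3; a stereocentre at a saturated ring carbon is drawn r in compound 1 and s in compound 3, so compound 3 is the mirror image of compound 1 with every stereocentre inverted. Going by the values given here, no measured pair here shows what inverting both centres does, so the direction of the step in this assay cannot be read from the data. Mirror images often bind quite differently, and the expected step from compound 1 to compound 3 is a 1.8-fold lower number from compound 1 to compound 3 (0.24 log units; within the scatter), with wide uncertainty. Compound 3 is therefore estimated at 80 nM, somewhere between 10 nM and 1000 nM.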

Compound 3, half-maximal inhibitory concentration: 2.5 nM
Compound 3: middle estimate off by 32-fold (1.51 log units), on the high side; measured number below the stated range.
By their numbers in this assay, from the lowest: compounds 2 and 3 (each within the scatter of the next); then compound 1.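

In this assay, inverting both stereocentres gives a 56-fold lower number from compound 1 to compound 3 (1.75 log units; beyond the scatter), so the assay clearly tells these two mirror images apart. The earlier compounds shown here could not show this, as they differ in more than their configuration. Here the step can be assigned to spatial arrangement alone, because no atom or bond changes: the fact that compounds 1 and 3 differ only in the configuration as drawn.

Both centres change together, so the compounds shown leave open whether one centre or the pair accounts for the step. As far as these compounds go, it also remains open whether the same inversion would shift the number similarly in compound 2, or in an analogue with an amide in place of the ester.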